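This account rests on a few compounds, and the source may have more. Where it says the series, first, only, none or still open, it means among the compounds named here.

Working notes on the series. Compound 1 `O=S(=O)(c1ccccc1)c1cn(C2CCNC2)c2ccccc12`, compound 2 `COc1ccc2c(c1)c(S(=O)(=O)c1cccc(F)c1)cn2C1CCCNC1` and compound 3 `COc1ccc2c(c1)c(S(=O)(=O)c1cccc(F)c1)cn2C1CCCN(C)C1` share one core, differing in the amine ring and in the substitution of the aromatic parts. In a functional assay on HeLa cells for agonist activity at 5-hydroxytryptamine receptor 6 (Homo sapiens), read by cAMP accumulation and immunoassay, with a stated time of 10 min (on this read-out higher numbers stand for larger maximal responses and lower numbers for smaller maximal responses), compound 1 gives 70%. In this assay compound 2 gives 75%, the higher of the two numbers available, but compound 1 sits within the usual scatter of it, so no order between the two is claimed. In this assay compound 3 gives "not determined" (no result reported), so no numeric result is available for it.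

Compound 4 `O=S(=O)(c1cccc(F)c1)c1cn(C2CCCNC2)c2ccccc12` is the next entry and has not been measured. It differs from compound 2 in one place: hydrogen in place of methoxy on an aromatic carbon. Going by the values given here, no step between two measured compounds isolates this change. Among the compounds with values here, the only related point is compound 1, which also carries no methoxy but differs from compound 2 elsewhere as well. In this assay compound 1 gives 70%, and that number lies within the scatter of the number of compound 2.

Expectation: in this assay compound 4 is estimated at 72%, with a range from 60% to 85%. The step this estimate implies, a number 3 percentage points lower from compound 2 to compound 4 (within the scatter), is expected to be small, not beyond the scatter, in no clear direction.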

Compound 4, largest response reached (Emax), in percent of the reference or control that the assay uses: 78%
Beside the measured number, compound 4's estimate is 6 percentage points below it; the range from low to high includes it.
By their numbers in this assay, from the lowest: compounds 1, 2 and 4 (each within the scatter of the next).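

In this assay, going by these compounds alone, exchanging methoxy for hydrogen gives a number 3 percentage points higher from compound 2 to compound 4 (within the scatter), the first step that isolates a single change. On this aromatic carbon, meta to a fused ring and para to a fused ring, the methoxy group is therefore not required for the largest response to stay at the level seen with it, which is a reading compound 1 could not give, as it differs from compound 2 in more than one place. No measurement at hand speaks to why this step stays within the scatter, so it is recorded as an observation only.

At this carbon the compounds shown hold only methoxy and hydrogen, so it remains open whether a hydroxyl group, an amine, a carboxylic acid or a longer chain such as butoxy would leave the largest response unchanged or move it beyond the scatter. As far as these compounds go, it also remains open whether the same exchange would give a similar step on a core with a different amine ring.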